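The compounds below may be only part of what the source reports. "The series", "measured", "known", "first", "only" and "open" are said of these compounds alone.

Measured so far in a functional assay on EA.hy 926 cells (Homo sapiens) for cytotoxicity, read by MTT assay, with stated times of 24 h and 12 h, tested at 100 uM; a lower number here means a weaker effect, a higher number a stronger effect of the compound at the concentration tested:
compound 1 `CCOC(=O)/C=C/c1ccc(OC(=O)c2nc(C)c(C)nc2C)c(O)c1`: 375%
compound 2 `CCOC(=O)/C=C/c1ccc(OC(=O)c2nc(C)c(C)nc2C)c(OC)c1`: 71.6%

Compound 1 stands highest of the two numbers; its nearest neighbour, compound 2, gives 71.6%. Within the data shown here, the only measured step, a number 303.4 percentage points lower from compound 1 to compound 2 (beyond the scatter), concerns the ring oxygen, where methyl replaces hydrogen, and it is large and beyond the scatter.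

Compound 3 `Cc1nc(C)c(C(=O)Oc2ccc(/C=C/C(=O)O)cc2O)nc1C` differs from compound 1 in another place: hydrogen in place of ethyl on an oxygen next to a carbonyl group. Put more widely, ethoxycarbonyl becomes carboxy. Among the measured compounds shown here, the ring oxygen keeps its hydrogen, as in compound 1, so the step from compound 1 to compound 2 does not bear on this change, and no measured step does. The expected step of a number 125 percentage points lower from compound 1 to compound 3 (beyond the scatter) is therefore set without a direction that the data support, and with a wide range. For compound 3 the estimate in this assay is 250%, with a range from 60% to 420%.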

Compound 3, a percentage reported as activity, at one concentration (the size of the read-out at that concentration, not a potency): 601%
Beside the measured number, compound 3's estimate is 351 percentage points below it; the measured number lies above the stated range.
By their numbers in this assay, from the lowest: compound 2; then compound 1; then compound 3.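

In this assay, the ethoxycarbonyl end of the chain proves to be a second place of large change: with hydrogen in place of ethyl on an oxygen next to a carbonyl group, the series shows a number 226 percentage points higher from compound 1 to compound 3 (beyond the scatter). The read-out therefore responds to the carboxy group as well as to the ring oxygen, where the earlier step was downward, a number 303.4 percentage points lower from compound 1 to compound 2 (beyond the scatter), so the two changes to compound 1 move the number in opposite directions. Nothing available bears on the origin of the rise with carboxy.

Still open, going by these compounds, is whether the rise is specific to the carboxylic acid or would also appear with a methyl ester, a longer alkyl ester or an amide at this place. Also open, on these data alone, is how methyl on the ring oxygen would act in a compound that carries the carboxy group.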